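Working notes: one side chain rearranged, compound 1 to compound 3

The source may report more compounds than this note shows. Statements on the series, on what has been measured and on what is new or still open speak of the compounds shown alone.

Measured so far:
compound 1 `C/N=C(/NC#N)NCCCCCCn1nc(-c2ccccc2)ccc1=O` — > 100 mg/kg
compound 2 `O=c1ccc(-c2ccccc2)nn1CCCCNC(=S)Nc1ccc(Cl)cc1` — > 100 mg/kg

In a functional assay on the whole organism (stomach) with Rattus norvegicus as the target (a lower number here means that less compound is needed, a higher number that more compound is needed for the effect), compound 1 gives only a limit, > 100 mg/kg, not a number. Compound 2 likewise returns only a limit, > 100 mg/kg. Within the data shown here, both measured values sit at the limit of > 100 mg/kg in this assay, at which 2 of the 2 values shown sit, so compound 1 stands with no measured number at all and no other compound of the set is placed any differently. Among the measured compounds shown here, no step between measured compounds can be drawn from this.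

Compound 3 `CN(C)/C(=N/CCCCCn1nc(-c2ccccc2)ccc1=O)NC#N` is the next candidate. It differs from compound 1 by a group of 8 heavy atoms (4 carbon, 4 nitrogen; no ring) in place of a group of 8 heavy atoms (4 carbon, 4 nitrogen; no ring), on a saturated chain carbon, five bonds along the chain from an aromatic nitrogen. For the measured compounds named here, since neither measured compound reaches a number, there is no measured step to lean on. The expected step of a number no higher from compound 1 to compound 3 (the limit leaves the size open) is none beyond the usual scatter of this assay. Compound 3 is estimated at 100 mg/kg, within 30 mg/kg to 300 mg/kg, and is expected most likely to be reported again only as a limit.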

Compound 3, dose for half-maximal effect: 81.5 mg/kg
Compound 3: the middle estimate sits 1.2-fold (0.09 log units) above what was measured, within the range that was stated.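

In this assay compound 3 is the only compound shown that returns a number rather than a limit, 81.5 mg/kg. Going by these compounds, the rearrangement of the side chain gives an at least 1.2-fold lower number from compound 1 to compound 3 (0.08 log units; that floor lies within the scatter), so a change on this saturated chain carbon, five bonds along the chain from an aromatic nitrogen, can bring the series to a measurable reading, although the true size of the step remains unknown. The other readings still give no number: the limit of > 100 mg/kg in this assay, at which 2 of the 3 values shown sit.

The compounds shown do not separate the parts of this rearrangement, so the step cannot be assigned to any single feature of the side chain. On these data alone, how a carboxylic acid or a primary amine at the end of the chain would read in this assay also stays open.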